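Trifluoromethyl for Methoxy: Cytotoxicity Expected to Stay Unreadable

The source may hold more compounds than are shown below. What is called first, only, known or untested is meant among the compounds shown, and "the series" means these compounds.

Compound 2 `CCOC(=O)c1c(-c2cccc(OC)c2)[nH]c2cc(OC)ccc2c1=O` carries a methoxy group on its pendant aromatic ring. In an ADME assay on BJ cells (Homo sapiens) for cytotoxicity, read by luminescence, with a stated time of 72 h (a lower number here means that less compound is needed, a higher number that more compound is needed for the effect), compound 2 gives only a limit, > 21500 nM. Compound 1 `C=Cc1cccc(-c2[nH]c3cc(OC)ccc3c(=O)c2C(=O)OCC)c1` likewise reaches only a limit, > 21500 nM. Compound 3 `CCOC(=O)c1c(-c2cccc(OCC(C)C)c2)[nH]c2cc(OC)ccc2c1=O` also stops at a limit, > 21500 nM. All three therefore sit at the limit of > 21500 nM in this assay, at which 3 of the 3 values shown sit, and the steps a step that the two limits leave unreadable from compound 1 to compound 2 and a step that the two limits leave unreadable from compound 2 to compound 3 cannot be sized. Compound 4 `CCOC(=O)c1c(-c2cccc(C(F)(F)F)c2)[nH]c2cc(OC)ccc2c1=O` differs from compound 2 by trifluoromethyl in place of methoxy on an aromatic carbon. Since the measured changes at this same aromatic carbon gave no readable size in this assay, no shift beyond the scatter is expected, and the expected step is a step that the limit leaves unreadable from compound 2 to compound 4. Compound 4 is thus estimated at 30000 nM, between 10000 nM and 100000 nM, most probably reported again only as a limit.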

Compound 4, half-maximal effective concentration: > 21500 nM
Compound 4: a limit, no number; the forecaster's own chance of this, stated with the estimate: 85%; the middle value lies beyond the limit too.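

Compound 4 also reaches only a limit, so its steps from compound 1, compound 2 and compound 3 cannot be read. The compounds shown leave open whether swapping these groups changes the concentration needed in this assay at all.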